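The source may hold more compounds than are shown below. What is called first, only, known or untested is meant among the compounds shown, and "the series" means these compounds.

Measured so far:
compound 1 `CCOC(=O)C1=C(Nc2ccccc2)S/C(=C\c2ccc(O)c(O)c2)C1=O` — 38.1%
compound 2 `CCOC(=O)C1=C(Nc2ccccc2)S/C(=C\c2ccccc2C(F)(F)F)C1=O` — < 10%

In a functional assay on MCF7 cells (Homo sapiens) for inhibition, read by MTT assay, with a stated time of 72 h, tested at 10 uM (on this read-out lower numbers stand for less inhibition and higher numbers for more inhibition at the one concentration tested (going by the name of the read-out)), compound 1 gives 38.1%. Among the two values shown it is the only actual number. For compound 2 the result < 10% is a limit of the assay, not a number. One of the two values thus sits at the limit of < 10% in this assay, at which 1 of the 2 values shown sits.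

Compound 3 `CCOC(=O)C1=C(Nc2ccccc2)S/C(=C\c2cc3ccncc3[nH]2)C1=O` has not yet been measured. Against compound 1 it shows (a group of 9 heavy atoms (7 carbon, 2 nitrogen; one five-membered aromatic ring with 1 hetero atom, one six-membered aromatic ring with 1 hetero atom) in place of a group of 8 heavy atoms (6 carbon, 2 oxygen; one six-membered aromatic ring of carbon only), on a double-bonded chain carbon bound to a double-bonded ring carbon). Within the data shown here, the two measured compounds differ at the same place, and no step between them is set out, so the size of the change expected here rests on the structural change alone. A step of moderate size in this assay, downward from compound 1, is expected from compound 1 to compound 3, possibly no larger than the scatter.

For compound 3 the estimate in this assay is 25%, expected to fall between 5% and 50%; the step this estimate means is a number 13.1 percentage points lower from compound 1 to compound 3 (beyond the scatter).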

Compound 3, a percentage reported as inhibition, at one concentration (the size of the read-out at that concentration, not a potency): 18.2%
Compound 3: the middle estimate sits 6.8 percentage points above what was measured; the range from low to high includes it.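

Among these compounds, replacing the 3,4-dihydroxyphenyl group with a group of one five-membered and one six-membered aromatic ring, each with one nitrogen, gives a number 19.9 percentage points lower from compound 1 to compound 3 (beyond the scatter) in this assay, the only step at this place that can be read as a number. Among the compounds shown here, the change lowers the inhibition, but compound 3 still gives a measured number, so the 3,4-dihydroxyphenyl group is not the only group at this place on the shared core that does. The result for compound 2 is a limit and not a number, so any step from it to compound 1 or compound 3 cannot be read: the limit of < 10% in this assay, at which 1 of the 3 values shown sits.

The compounds shown swap the whole group at once, so they leave open whether the lower value of compound 3 comes with the loss of the two hydroxyl groups or with the new ring pair, which a plain phenyl or a 4-hydroxyphenyl group at this place could help separate. Also open, from the compounds shown here alone, is how a 4-aminophenyl or a 4-methoxyphenyl group would behave there, and all of these readings come from one concentration, so they give no potency.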